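Ring contraction and loss of hydroxy on the lactam

The source may report more compounds than this note shows. Statements on the series, on what has been measured and on what is new or still open speak of the compounds shown alone.

Measured compounds:
compound 1 `CC(C)c1noc(N2CCC(Oc3cc(N4CCc5cc(N6CCCCC6=O)ccc54)ncn3)CC2)n1` — an assay on CHO cells for agonist activity at Glucose-dependent insulinotropic receptor (Homo sapiens), read by a luciferase reporter and cAMP accumulation, with a stated time of 2 h; a lower number here means that less compound is needed, a higher number that more compound is needed for the effect: 17 nM
compound 2 `CC(C)c1noc(N2CCC(Oc3cc(N4CCc5cc(N6CC(O)CCC6=O)ccc54)ncn3)CC2)n1` — this assay: 90 nM

Compound 2 stands highest of the two numbers; its nearest neighbour is compound 1, and the step of a 5.3-fold higher number from compound 1 to compound 2 (0.72 log units; beyond the scatter) separates them. Compound 3 `CC(C)c1noc(N2CCC(Oc3cc(N4CCc5cc(N6CCCC6=O)ccc54)ncn3)CC2)n1` is not yet measured. It differs from compound 2 by 2-oxopyrrolidin-1-yl in place of 5-hydroxy-2-oxopiperidin-1-yl on an aromatic carbon: the hydroxy is gone and the lactam ring is one atom smaller.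

For the measured compounds named here, only one measured step bears on this change. The step of a 5.3-fold higher number from compound 1 to compound 2 (0.72 log units; beyond the scatter) shows that adding the hydroxy to the saturated ring carbon raised the number beyond the scatter, so its removal in compound 3 is expected to give back most of that ground. The ring contraction itself has no measured precedent among these compounds, and its effect is unknown. Compound 3 is therefore expected to land near compound 1 rather than compound 2, with the estimated step of a 3.6-fold lower number from compound 2 to compound 3 (0.56 log units; beyond the scatter) in this assay. The estimate for compound 3 is 25 nM, within a range from 9 nM to 70 nM.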

Compound 3, half-maximal effective concentration: 33 nM
The estimate for compound 3 lay 1.3-fold (0.12 log units) below the measured number, and the stated range covers the measured number.
By their numbers in this assay, from the lowest: compounds 1 and 3 (each within the scatter of the next); then compound 2.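

Compound 3 shows that this position, on an aromatic carbon meta to a fused ring and para to a fused ring, tolerates a five-membered lactam as well as a six-membered one in this assay. Replacing 2-oxopiperidin-1-yl with 2-oxopyrrolidin-1-yl gives a 1.9-fold higher number from compound 1 to compound 3 (0.29 log units; within the scatter) and so leaves the number within the scatter, whereas the combined change of ring size and loss of the hydroxy gives a 2.7-fold lower number from compound 2 to compound 3 (0.44 log units; beyond the scatter) and lies beyond it. Together with the earlier hydroxy step, this places compound 2 apart from both lactams without a hydroxy, although no measurement offered here explains the difference.

The compounds shown leave open whether a hydroxy on the five-membered lactam would raise the number as it does on the six-membered ring, since the hydroxy has been compared only on the latter. They also leave open whether the ring itself is needed, as an open-chain acetamide at this position would test, and how a primary amine or a carboxylic acid on the lactam ring would read in this assay in place of the hydroxy.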